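Swapping the halogenated phenyl ring on the shared core

The source may hold more compounds than are shown below. What is called first, only, known or untested is meant among the compounds shown, and "the series" means these compounds.

Compound 1, `COc1ccc(C(=O)/C=C/c2cc(OC)c(OC)c(OC)c2)c2c1C=CC(C)(C)O2`: 9150 nM
Compound 2, `COc1ccc(C(=O)/C=C/c2cccc(F)c2)c2c1C=CC(C)(C)O2`: > 10000 nM

Both compounds were tested in a functional assay on SW-620 cells (Homo sapiens) for antiproliferative activity, read by MTT assay, with a stated time of 24 h; a higher number here means a weaker inhibitor, a lower number a stronger inhibitor. Compound 1 gives 9150 nM, a weak result. For compound 2 the assay reports only a limit and not a number, namely > 10000 nM. Compound 2 therefore stands at the limit of > 10000 nM in this assay, at which 1 of the 2 values shown sits, and all that can be said of the pair is that both results point to weak inhibition, with no order between them.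

Compound 3, `COc1ccc(C(=O)/C=C/c2ccccc2Cl)c2c1C=CC(C)(C)O2`, has not yet been tested. It differs from compound 2 in one place: 2-chlorophenyl in place of 3-fluorophenyl on a double-bonded chain carbon bound to a double-bonded chain carbon. A halogen-bearing phenyl ring remains, only the halogen and where it sits on that ring change. Within the data shown here, since compound 2 sits at the limit of > 10000 nM in this assay, at which 1 of the 2 values shown sits, there is no measured step to lean on. The change from compound 2 to compound 3 is expected to give no step beyond the usual scatter, a step that the limit leaves unreadable from compound 2 to compound 3. In this assay compound 3 is therefore expected to come out at about 12000 nM, within a range of 4000 nM to 40000 nM, with a fair chance that again only a limit is reported.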

Compound 3, half-maximal inhibitory concentration: > 10000 nM
Compound 3 ended at the assay's limit (the forecaster's own chance of this, stated with the estimate: 60%); the middle value lies beyond the limit too.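

No step can be read between compound 2 and compound 3, because both results are limits and not numbers: the limit of > 10000 nM in this assay, at which 2 of the 3 values shown sit. The compounds shown leave open how far apart compound 2 and compound 3 truly lie in this assay, and whether 2-chlorophenyl in place of 3-fluorophenyl changes the result at all.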